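The compounds below may be only part of what the source reports. "The series", "measured", "known", "first", "only" and "open" are said of these compounds alone.

In a functional assay on MCF7 cells (Homo sapiens) for cytotoxicity, read by MTT assay, with a stated time of 72 h (a lower number here means a stronger inhibitor, a higher number a weaker inhibitor), the measured compounds read as follows:

- Compound 1 `CCC(C)=C1C(=O)N(c2ccc(Cl)cc2)N(c2ccc(Cl)cc2)C1=O` gives 41600 nM
- Compound 2 `O=C1C(=Cc2ccc(F)cc2)C(=O)N(c2ccc(Cl)cc2)N1c1ccc(Cl)cc1` gives 31400 nM
- Compound 3 `COc1cc(C=C2C(=O)N(c3ccc(Cl)cc3)N(c3ccc(Cl)cc3)C2=O)ccc1O` gives 22800 nM

Compound 2 lies within the scatter of both compound 1 and compound 3, so it stands apart from neither. Compound 4 `COc1ccc(C=C2C(=O)N(c3ccc(Cl)cc3)N(c3ccc(Cl)cc3)C2=O)cc1` carries methoxy in place of fluoro on an aromatic carbon, para to a large group (methoxy in place of fluoro on an aromatic carbon). Among the measured compounds shown here, the only measured step bearing on this change is a 1.4-fold lower number from compound 2 to compound 3 (0.14 log units; within the scatter) (4-hydroxy-3-methoxyphenyl in place of 4-fluorophenyl) and it lies within the scatter. In this assay no step beyond the scatter is therefore expected, in either direction. The expected step is a 1.1-fold lower number from compound 2 to compound 4 (0.05 log units; within the scatter) and it stays within the scatter. Compound 4 is estimated at 28000 nM (expected range 14000 nM to 55000 nM).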

Compound 4, half-maximal inhibitory concentration: > 128000 nM
Compound 4 gave a limit, no number; the forecaster's own chance of this, stated with the estimate: 5%; middle value at least 4.5-fold (0.66 log units) from the limit.
By their numbers in this assay, from the lowest: compounds 3, 2 and 1 (each within the scatter of the next). At a limit, above all of these: compound 4.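

In this assay, compound 4 gives a limit, not a number: the limit of > 128000 nM in this assay, at which 1 of the 4 values shown sits. The earlier step on this aryl group stayed within the scatter, whereas methoxy for fluoro at this one position gives an at least 4.0-fold higher number from compound 2 to compound 4 (0.61 log units; beyond the scatter), so the position is not indifferent to substitution. A 4-hydroxy-3-methoxyphenyl group also carries methoxy, yet the change to 4-methoxyphenyl gives an at least 5.6-fold higher number from compound 3 to compound 4 (0.74 log units; beyond the scatter), so methoxy alone does not account for the shift.

As far as these compounds go, the full size of both steps remains open, as both rest on a limit. From the compounds shown here alone, how an amine or a carboxylic acid at this position would read also remains open.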